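The source may hold more compounds than are shown below. What is called first, only, known or untested is meant among the compounds shown, and "the series" means these compounds.

Compound 1 `Cc1ccc(NC(=O)c2cccc(C(F)(F)F)c2)cc1N1Cc2cnc(Nc3ccc(C)c(C(F)(F)F)c3)nc2N(C)C1=O` in an ADME assay on BaF3 cells (Mus musculus) for antiproliferative activity, read by CellTiter-Glo and CCK-8 assay, with a stated time of 72 h (a lower number here means a stronger inhibitor of growth, a higher number a weaker inhibitor of growth), gives > 10000 nM, which is a limit of the assay rather than a number.
Compound 2 `Cc1ccc(Nc2ncc3c(n2)N(C)C(=O)N(c2cc(NC(=O)c4cccc(C(F)(F)F)c4)ccc2C)C3)cc1N(C)C` in this assay gives > 10000 nM, also a limit of the assay.

Compound 2 therefore stands at the assay limit, where (the limit of > 10000 nM in this assay, at which 2 of the 2 values shown sit). Among the compounds with values here, the only step seen, a step that the two limits leave unreadable from compound 1 to compound 2, runs between two limits and its size cannot be read. Compound 3 `Cc1ccc(NC(=O)c2cccc(C(F)(F)F)c2)cc1N1Cc2cnc(O[C@H]3CCNC3)nc2N(C)C1=O` differs from compound 2 by (pyrrolidin-3-yl)oxy in place of (3-(dimethylamino)-4-methylphenyl)amino on an aromatic carbon. Within the data shown here, no measured step bears on this change, so the data give no direction for it. Compound 3 is expected to give about 6000 nM, between 1000 nM and 20000 nM, an estimated step of an at least 1.6-fold lower number from compound 2 to compound 3 (0.22 log units; that floor lies within the scatter) held only loosely.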

Compound 3, concentration for 50% growth inhibition: > 10000 nM
Compound 3: no number, only a limit; the forecaster's own chance of this, stated with the estimate: 55%; middle value at least 1.6-fold (0.22 log units) away from the limit.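

Compound 3 joins compound 1 and compound 2 at the assay limit, so no step among the three can be read: the limit of > 10000 nM in this assay, at which 3 of the 3 values shown sit.

On these data alone, whether any of these changes to the shared core alters growth inhibition at all remains open.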